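From Hydroxyethyl to Carboxyethyl on an Amide Nitrogen

A few compounds are considered here, and "the series" means these few. Any claim that something is new, unique, unknown or untested is made for them only; others in the source may bear on it.

Two related compounds have been tested so far in a functional assay on MCF7 cells (Homo sapiens) for cytotoxicity, read by MTT assay, with a stated time of 48 h (on this read-out higher numbers stand for weaker inhibition and lower numbers for stronger inhibition), and their numbers lie far apart. Compound 1 (`CCC(CC)(c1ccc(OCC(O)C(C)(C)C)c(C)c1)c1ccc(C(=O)N[C@H](CO)CCO)n1C`) gives 7.83 nM there, while compound 2 (`CCn1c(C(=O)NCCO)ccc1C(CC)(CC)c1ccc(OCC(O)C(C)(C)C)c(C)c1`) gives 1810 nM as the higher number of the two, which means weaker inhibition, and the gap lies beyond the usual scatter. These two compounds differ in more than one place, so the gap cannot be tied to any single change. Compound 3 (`CCn1c(C(=O)N[C@@H](C)C(=O)O)ccc1C(CC)(CC)c1ccc(OCC(O)C(C)(C)C)c(C)c1`) differs from compound 2 by having 1-carboxyethyl in place of 2-hydroxyethyl on an amide-type nitrogen. Going by the values given here, no measured pair shows this change, so in this assay no step beyond the scatter is expected in either direction, though the uncertainty is wide. The expected change is a 1.2-fold lower number from compound 2 to compound 3 (0.08 log units; within the scatter) on this estimate. Compound 3 is estimated at 1500 nM (expected range 200 nM to 8000 nM).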

Compound 3, half-maximal inhibitory concentration: 180 nM
Beside the measured number, compound 3's estimate is 8.3-fold (0.92 log units) above it; the measured number lies below the stated range.
By their numbers in this assay, from the lowest: compound 1; then compound 3; then compound 2.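

On the amide-type nitrogen of the shared core, 1-carboxyethyl in place of 2-hydroxyethyl gives a 10-fold lower number from compound 2 to compound 3 (1.00 log units; beyond the scatter) in this assay, a step beyond the scatter. Going by these compounds alone, this is the only change here confined to one place, so it ties a clear difference in the read-out to the group on this nitrogen, which the gap between the earlier two compounds could not do. No supporting data bear on why the number moves.

The step swaps the whole group, so it cannot say whether the carboxylic acid end or the branched chain with its defined stereocentre matters more. Carboxymethyl on the same nitrogen would keep the acid without the branch, while 2-aminoethyl would show how a chain ending in an amine compares with compound 2.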